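The source may report more compounds than this note shows. Statements on the series, on what has been measured and on what is new or still open speak of the compounds shown alone.

Measured so far:
compound 1 `CCc1cccc2c(O)c(-c3occ(C)c3C(=O)O)ccc12`, 7 ug/mL in a functional assay on KBVIN cells (Homo sapiens) for cytotoxicity, read by MTT assay, with a stated time of 72 h; a lower number here means that less compound is needed, a higher number that more compound is needed for the effect;
compound 2 `CCCOC(=O)c1c(C)coc1-c1ccc2c(CC)cccc2c1OC`, > 10 ug/mL in this assay, which is a limit of the assay and not a number;
compound 3 `CCc1cccc2c(OC(C)=O)c(-c3occ(C)c3COC(C)=O)ccc12`, > 10 ug/mL in this assay, also a limit and not a number.

Compound 2 stands at the limit, and the limit of > 10 ug/mL in this assay, at which 2 of the 3 values shown sit, shows that it shares that position with one other compound. Compound 4 `CCc1cccc2c(OC)c(-c3occ(C)c3COCC(F)(F)F)ccc12` differs from compound 2 in one place: (2,2,2-trifluoroethoxy)methyl in place of propoxycarbonyl on an aromatic carbon. Going by the values given here, no measured pair shows what such a change does, so the expected step from compound 2 to compound 4 is none beyond the scatter, a step that the limit leaves unreadable from compound 2 to compound 4. Compound 4 is therefore estimated at 15 ug/mL, within 6 ug/mL to 40 ug/mL, most likely reported again as a limit.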

Compound 4, concentration for half-maximal effect: 6 ug/mL
Compound 4: the middle estimate sits 2.5-fold (0.40 log units) above what was measured; low and high end bracket the measured number.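

In this assay compound 2 gives > 10 ug/mL, which is a limit of the assay and not a number. Putting (2,2,2-trifluoroethoxy)methyl in place of propoxycarbonyl at this place gives an at least 1.6-fold lower number from compound 2 to compound 4 (0.22 log units; that floor lies within the scatter), so this position can carry the new group and still yield a real number. The full size of the step stays unknown because one end of it is only a limit: the limit of > 10 ug/mL in this assay, at which 2 of the 4 values shown sit.

Still open, on these data alone, is whether the fluorine atoms matter, which a plain ethoxymethyl group at this place would show. As far as these compounds go, what an amine there would do also remains open.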